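This account rests on a few compounds, and the source may have more. Where it says the series, first, only, none or still open, it means among the compounds named here.

Three compounds share a core built from a fluorinated naphthyl group on a pyridinone ring, with a branched side chain carrying a small five-membered ring. Compound 1 `CC(C)C(/C=C1\NC(=O)NC1=O)c1ccc(-c2ccc3cccc(F)c3c2)[nH]c1=O` is tested in a functional assay on CHO cells for antagonist activity at prostaglandin E2 receptor EP3 subtype (Homo sapiens), read by cAMP accumulation, with a stated time of 30 min (on this read-out lower numbers stand for stronger inhibition and higher numbers for weaker inhibition), and gives 87 nM. Compound 3 `CCC(/C=C1\OC(=O)NC1=O)(CC)c1ccc(-c2ccc3cccc(F)c3c2)[nH]c1=O` gives 61 nM in this assay, and compound 2 `CC(C)[C@@H](c1ccc(-c2ccc3cccc(F)c3c2)[nH]c1=O)[C@@H]1OC(=O)NC1=O` gives 610 nM. Among these three numbers compound 1 stands second highest: compound 3 lies within the usual scatter of it, while compound 2 lies clearly beyond the scatter, with the higher number.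

Compound 4 `CC(C)C(c1ccc(-c2ccc3cccc(F)c3c2)[nH]c1=O)C1NC(=O)NC1=O` has not yet been measured. It differs from compound 1 in one place: a group of 7 heavy atoms (3 carbon, 2 nitrogen, 2 oxygen; one five-membered non-aromatic ring with 2 hetero atoms) in place of a group of 8 heavy atoms (4 carbon, 2 nitrogen, 2 oxygen; one five-membered non-aromatic ring with 2 hetero atoms), on a saturated chain carbon bound to an aromatic carbon and a saturated chain carbon. The linking double bond of compound 1 is gone, and the ring sits directly on the chain carbon.

Within the data shown here, no measured pair follows exactly this change. The closest hint comes from compound 3 and compound 2. Compound 3, whose ring is attached through a double bond, gives 61 nM. Compound 2, whose ring is directly attached, gives 610 nM. On that basis the step from compound 1 to compound 4 is expected to raise the number beyond the scatter, estimated as a 4.6-fold higher number from compound 1 to compound 4 (0.66 log units; beyond the scatter). Compound 4 is therefore expected to give about 400 nM, within a range of 120 nM to 1500 nM.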

Compound 4, half-maximal inhibitory concentration: 320 nM
Beside the measured number, compound 4's estimate is 1.3-fold (0.10 log units) above it; low and high end bracket the measured number.
By their numbers in this assay, from the lowest: compounds 3 and 1 (each within the scatter of the next); then compounds 4 and 2 (each within the scatter of the next).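

Taking away the linking double bond and setting 2,5-dioxoimidazolidin-4-yl directly on the saturated chain carbon gives a 3.7-fold higher number from compound 1 to compound 4 (0.57 log units; beyond the scatter) in this assay, which means weaker inhibition. Compounds 2 and 3 differ in more than one place and could only hint at this, whereas this pair changes the attachment alone, so the effect is now measured as a single step, and the size of the step shows that at this position inhibition falls but is not lost, with compound 4 still at 320 nM. No measurement shown here explains why the number rises with this change.

On these data alone, it remains open whether the double bond itself matters or only the way the ring is held away from the chain carbon, which a saturated methylene link between that carbon and the ring would help to separate. Also open, as far as these compounds go, are how the two spatial arrangements at the new ring carbon of compound 4 compare, and whether a carboxylic acid could take the place of the ring at this position.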